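The source may hold more compounds than are shown below. What is called first, only, known or untested is meant among the compounds shown, and "the series" means these compounds.

In a functional assay on QGY cells (Homo sapiens) for cytotoxicity, read by MTT assay, with a stated time of 48 h (on this read-out lower numbers stand for stronger inhibition and higher numbers for weaker inhibition), compound 1 `CCOC(=O)C1(C(=O)Nc2ccccc2)CC1c1cc(OC)c(OC)c(OC)c1` gives 59300 nM; > 100000 nM (2 entries), with several entries shown for it in this assay (the several entries of compound 1 in this assay, 59300 nM; > 100000 nM (2 entries)). Compound 2 `COc1cc([C@H]2C[C@@]2(CO)C(=O)Nc2ccccc2)cc(OC)c1OC` is known in this assay only as a limit, > 100000 nM, so its standing cannot be fixed more closely than that. Compound 3 `COc1cc([C@H]2C[C@@]2(CO)C(=O)NCc2ccc(C)cc2)cc(OC)c1OC` likewise gives only a limit, > 100000 nM. The step from compound 2 to compound 3, a step that the two limits leave unreadable from compound 2 to compound 3, which puts 4-methylbenzyl in place of phenyl on the amide-type nitrogen, therefore cannot be read in size, since both ends sit at the same limit (the limit of > 100000 nM in this assay, at which 2 of the 3 values shown sit).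

Compound 4 `COc1cc([C@@H]2C[C@@]2(CO)C(=O)Nc2ccccc2)cc(OC)c1OC` is now to be measured in this assay. Its change from compound 2 is the two compounds have the same atoms and bonds and differ only in configuration as drawn: 1 of 2 stereo elements differ; a stereocentre at a saturated ring carbon is drawn R in compound 2 and S in compound 4. Among the compounds with values here, no measured step concerns a change of configuration alone, so the only guide is where compound 2 itself stands, and that is a limit. The expected step from compound 2 to compound 4 is therefore a step that the limit leaves unreadable from compound 2 to compound 4, with no direction beyond the scatter that the numbers would support. For compound 4 the estimated half-maximal inhibitory concentration is 120000 nM, within the range 30000 nM to 400000 nM, with a strong chance that the assay again reports only a limit.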

Compound 4, half-maximal inhibitory concentration: 36700 nM
Estimate against measurement, compound 4: 3.3-fold (0.51 log units) above; measured number inside the range.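

Configuration at a saturated ring carbon, a change that no earlier comparison touched, has a readable effect in this assay: the change from the one drawn form to the other gives an at least 2.7-fold lower number from compound 2 to compound 4 (0.43 log units; beyond the scatter). Nothing else separates the pair, so this shift belongs to that single stereocentre alone: the fact that compounds 2 and 4 differ only in the configuration as drawn. The result also gives the series a firm number with the phenyl amide in place, whereas the earlier step on the amide-type nitrogen, which put 4-methylbenzyl in place of phenyl, cannot be read, since both of its ends sit at a limit: the limit of > 100000 nM in this assay, at which 2 of the 4 values shown sit.

From the compounds shown here alone, the full size of the configuration step stays open, as does the question of whether the same inversion would also lower the number with 4-methylbenzyl on the amide-type nitrogen, since compound 3 is known only as a limit. Going by these compounds, it is also open whether the second stereo element, which compound 2 and compound 4 share, matters in the same way, and whether a carboxylic acid or an amine in place of the hydroxymethyl group would keep the number that compound 4 reaches.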